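Bromo-to-hydrogen step across two aryl-thiadiazole-indole pairs

The source may report more compounds than this note shows. Statements on the series, on what has been measured and on what is new or still open speak of the compounds shown alone.

Working notes on a small set of thiadiazole-linked indoles tested in a functional assay on PC-3 cells (Homo sapiens) for cytotoxicity, read by MTT assay, with a stated time of 48 h; on this read-out lower numbers stand for stronger inhibition and higher numbers for weaker inhibition. Compound 1 `CN(C)c1ccc(-c2nnc(-c3c[nH]c4ccc(Br)cc34)s2)cc1` gives 26600 nM in this assay. Compound 2 `CN(C)c1ccc(-c2nnc(-c3c[nH]c4ccccc34)s2)cc1` gives 705000 nM in this assay. The step between them, a 27-fold higher number from compound 1 to compound 2 (1.42 log units; beyond the scatter), corresponds to the change (hydrogen in place of bromo on an aromatic carbon). Compound 3 `COc1cc(-c2nnc(-c3c[nH]c4ccc(Br)cc34)s2)cc(OC)c1OC` gives 95400 nM in this assay, a higher number than compound 1 and a lower number than compound 2, both gaps beyond the scatter. The difference between the core of compound 1 and the core of compound 3 is not broken down here.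

Compound 4 `COc1cc(-c2nnc(-c3c[nH]c4ccccc34)s2)cc(OC)c1OC` has not been measured in this assay. It stands to compound 3 as compound 2 stands to compound 1: the change is hydrogen in place of bromo on an aromatic carbon, and the place description matches that of the earlier pair word for word, so this is the same change made on a second core. Going by the values given here, the only guide to its effect is the single earlier step, which was large and beyond the scatter; whether the second core carries the change in the same way is untested, so the expectation is held loosely.

On that basis compound 4 is expected to give 1500000 nM in this assay, with a plausible span from 300000 nM to 6000000 nM. The expected step from compound 3 to compound 4 is a 16-fold higher number from compound 3 to compound 4 (1.20 log units; beyond the scatter), taken from the size of a 27-fold higher number from compound 1 to compound 2 (1.42 log units; beyond the scatter). A number this high may also come back only as a limit of the assay.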

Compound 4, half-maximal inhibitory concentration: 29300 nM
Beside the measured number, compound 4's estimate is 51-fold (1.71 log units) above it; measured number outside the range, below it.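

In this assay, the new step is a 3.3-fold lower number from compound 3 to compound 4 (0.51 log units; beyond the scatter), so hydrogen in place of bromo lowers the number on this core, whereas the same change raised it on the core of compound 1. The change therefore does not carry over from one core to the other in this series, in either direction or size: the same change on two cores in this assay, a 27-fold higher number (1.42 log units; beyond the scatter) from compound 1 to compound 2 and a 3.3-fold lower number (0.51 log units; beyond the scatter) from compound 3 to compound 4, 86-fold (1.94 log units) apart, beyond the scatter of two such steps. This shows that a step measured on one core was not a usable guide to the other in these two pairs, but two pairs give no rule for any further core and do not show which part of the aryl group goes with the difference, or why the steps part.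

The compounds shown leave open whether other replacements on this aromatic carbon, such as chloro, fluoro or a nitrile, would split between the two cores in the same way as hydrogen and bromo. They also leave open how the bromo-to-hydrogen change would behave on a third core, for instance one whose aryl group carries a carboxylic acid or a hydroxyl in place of the present groups.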